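The source may hold more compounds than are shown below. What is called first, only, known or untested is meant among the compounds shown, and "the series" means these compounds.

Of the compounds shown here, three have so far been measured in a functional assay on the whole organism for inhibition, with Rattus norvegicus as the target, with stated times of 1 h and 3.5 h, at a dose of 100 mg/kg by the oral route; on this read-out lower numbers stand for less inhibition and higher numbers for more inhibition at the one dose given (going by the name of the read-out). Compound 1 `CCOC(=O)Nc1nccc(-c2ccncc2)n1` gives 31% in this assay, and compound 2 `CN1CCc2ncncc2C1` gives 50%. Compound 3 `CC(C)(C)c1nc(-c2ccccc2)ncc1-c1ccccc1` reaches only a limit of the assay, < 5%, which is the limit of < 5% in this assay, at which 1 of the 3 values shown sits. Compound 3 thus stands at the bottom of the values shown, with both compound 1 and compound 2 clearly above it. Compound 4 `CNc1ncc(-c2ccccc2)c(C(C)(C)C)n1` has not yet been measured; it differs from compound 3 by methylamino in place of phenyl on an aromatic carbon. Since compound 1 gives 31% and compound 2 gives 50%, the step is expected to be upward and beyond the usual scatter, a number at least 17 percentage points higher from compound 3 to compound 4 (beyond the scatter). Compound 4 is accordingly expected to give about 22% in this assay, within a range from 5% to 45%.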

Compound 4, a percentage reported as inhibition, in the whole organism at one dose (the size of the read-out at that dose, not a potency): 37%
Estimate against measurement, compound 4: 15 percentage points below, and the stated range covers the measured number.
By their numbers in this assay, from the lowest: compounds 1 and 4 (each within the scatter of the next); then compound 2. At a limit, below all of these: compound 3.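

In this assay, methylamino in place of phenyl on the aromatic carbon between two ring nitrogen atoms yields a number at least 32 percentage points higher from compound 3 to compound 4 (beyond the scatter), the first view of what this position does to the read-out. The result shows that the read-out depends on the group at this place. The value of compound 3 is a limit and not a number, so the step has a floor but no known size: the limit of < 5% in this assay, at which 1 of the 4 values shown sits.

The compounds shown leave open whether a plain amine, dimethylamino or a longer chain such as propylamino at this position would read like compound 4. They also leave open whether the same change would hold on another core.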